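Hydroxamic acid series: para-substituent swap and membrane passage

The source may report more compounds than this note shows. Statements on the series, on what has been measured and on what is new or still open speak of the compounds shown alone.

Measured so far:
compound 1 `CC(C)(C)c1ccc(CCCN2CC=C(CCC(=O)NO)C2=O)cc1` gives 15 nm/s
compound 2 `O=C(CCC1=CCN(Cc2ccc(F)cc2)C1=O)NO` gives 19.3 nm/s

In an ADME assay for permeability, using PAMPA (a lower number here means that the compound crosses the layer more slowly, a higher number that the compound crosses the layer faster), compound 2 gives 19.3 nm/s, the nearest number being that of compound 1 at 15 nm/s, which sits within the usual scatter of it; the two do not separate.

Compound 3 `O=C(CCC1=CCN(Cc2ccc(Br)cc2)C1=O)NO` is not yet measured. It differs from compound 2 by bromo in place of fluoro on an aromatic carbon.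

Going by the values given here, no step between measured compounds is available, so nothing anchors the size of this change. The step from compound 2 to compound 3 is expected as a 1.3-fold higher number from compound 2 to compound 3 (0.11 log units; within the scatter), a shift not beyond the scatter. Compound 3 is expected at 25 nm/s, with a range of 12 nm/s to 50 nm/s.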

Compound 3, apparent permeability: 10.2 nm/s
For compound 3 the middle estimate is 2.5-fold (0.39 log units) above the measured one; measured number outside the range, below it.
By their numbers in this assay, from the lowest: compounds 3, 1 and 2 (each within the scatter of the next).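

In this assay, the series now has its first single-place step: bromo in place of fluoro on an aromatic carbon, para to a large group, gives a 1.9-fold lower number from compound 2 to compound 3 (0.28 log units; within the scatter) and stays within the scatter. At this position, the two halogens therefore do not separate compound 2 from compound 3 in this read-out. No measurement available here accounts for the size of this step.

As far as these compounds go, whether an amine or a carboxylic acid at the same place would separate from compound 2 remains open. From the compounds shown here alone, the effect of a longer chain alone also remains open, as compound 1 differs from compound 2 in more than one place.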